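The compounds below may be only part of what the source reports. "The series", "measured", "known", "first", "only" and "open" are said of these compounds alone.

Measured in an ADME assay on HEK293 cells (Homo sapiens) for inhibition, read by MTT assay, with stated times of 18 h and 4 h; a lower number here means a stronger inhibitor, a higher number a weaker inhibitor:
- Compound 1, `CCCCCCCCCCOP(=O)(O)OCCSC(=S)N1CCCCCC1`: 70000 nM
- Compound 2, `CCCCCCCCCCCCCCCCOP(=O)(O)OCCSC(=S)N1CCN(C)CC1`: > 100000 nM
- Compound 3, `CCCCCCCCCCOP(=O)(O)OCCSC(=S)N1CCN(C)CC1`: not yet measured

Only one of the two measured compounds has an exact number. Compound 2 gives > 100000 nM, which is a limit of the assay and not a number. Compound 2 therefore stands at the limit of > 100000 nM in this assay, at which 1 of the 2 values shown sits.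

Compound 3 differs from compound 2 in one place, and the change shortens the long chain: hydrogen in place of hexyl on a saturated chain carbon, ten or more bonds along the chain from an oxygen on an unsaturated carbon. Cut one bond further out, the same difference reads nonyl to propyl.

Among the compounds with values here, no measured pair of compounds shows what a change of this kind does in this assay, so any forecast here is uncertain. Within the data shown here, the one exact number is that compound 1 gives 70000 nM, so a large move towards strong inhibition is not expected. The estimated change is an at least 1.2-fold lower number from compound 2 to compound 3 (0.09 log units; that floor lies within the scatter), a small step towards stronger inhibition that may not go beyond the usual scatter.

Compound 3 is expected at 80000 nM, with an estimated range of 35000 nM to 160000 nM.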

Compound 3, half-maximal inhibitory concentration: > 100000 nM
Compound 3 ended at the assay's limit; the forecaster's own chance of this, stated with the estimate: 45%; middle value at least 1.2-fold (0.09 log units) away from the limit.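

In this assay compound 3 gives > 100000 nM, which is a limit of the assay and not a number. Cutting the long chain at this place therefore does not bring the value down to an exact number, but the step between the two chain lengths cannot be read, and any change hidden behind the limit stays unseen: the limit of > 100000 nM in this assay, at which 2 of the 3 values shown sit. With the chain kept the same, 4-methylpiperazin-1-yl in place of azepan-1-yl on a thiocarbonyl carbon gives an at least 1.4-fold higher number from compound 1 to compound 3 (0.15 log units; that floor lies within the scatter), so the one exact value in the set now has a comparison that changes only one place, although this step shows only a floor and not a true size.

The compounds shown leave open what the long chain does when azepan-1-yl sits on the thiocarbonyl carbon, since only one chain length is seen with that ring. They also leave open whether another group in that place, such as morpholine, or a still shorter chain, such as hexyl, would give an exact number in this assay.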